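A few compounds are considered here, and "the series" means these few. Any claim that something is new, unique, unknown or untested is made for them only; others in the source may bear on it.

In a series built on one shared core, three compounds have so far been measured in an assay on membranes from brain for displacement of a labelled ligand from Neuronal acetylcholine receptor; alpha4/beta2 (Rattus norvegicus); on this read-out lower numbers stand for stronger inhibition and higher numbers for weaker inhibition. Compound 1 `CCCCc1cncc(OC[C@@H]2CCCN2C)c1` gives 0.16 nM in this assay, compound 2 `CC(C)Cc1cncc(OC[C@@H]2CCCN2C)c1` gives 0.21 nM, and compound 3 `CC(=O)c1cncc(OC[C@@H]2CCCN2C)c1` gives 1.19 nM. Compound 3 therefore stands at the highest number of the three: the step of a 7.4-fold higher number from compound 1 to compound 3 (0.87 log units; beyond the scatter) and the step of a 5.7-fold higher number from compound 2 to compound 3 (0.75 log units; beyond the scatter) both lie beyond the scatter, whereas the step of a 1.3-fold higher number from compound 1 to compound 2 (0.12 log units; within the scatter) lies within it.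

The next compound, compound 4 `COC(=O)c1cncc(OC[C@@H]2CCCN2C)c1`, differs from compound 3 by methoxy in place of methyl on a carbonyl carbon. Going by the values given here, the two steps that bear on this part of the molecule, a 7.4-fold higher number from compound 1 to compound 3 (0.87 log units; beyond the scatter) and a 5.7-fold higher number from compound 2 to compound 3 (0.75 log units; beyond the scatter), both concern the exchange of a plain alkyl chain for the acetyl group and were modest in size; neither of them alters a group already attached to a carbonyl carbon, so no measured step maps directly onto the methyl-to-methoxy exchange. The carbonyl that appears to cost binding relative to compound 1 and compound 2 is kept in compound 4. The account therefore expects a small step in this assay, if any, in either direction, and most likely not beyond the scatter. For compound 4 the estimated value in this assay is 1.5 nM, with a range from 0.5 nM to 5 nM. The expected step is a 1.3-fold higher number from compound 3 to compound 4 (0.10 log units; within the scatter).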

Compound 4, inhibition constant: 1.45 nM
Beside the measured number, compound 4's estimate is 1.0-fold (0.01 log units) above it; measured number inside the range.
By their numbers in this assay, from the lowest: compounds 1 and 2 (each within the scatter of the next); then compounds 3 and 4 (each within the scatter of the next).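

In this assay, going by these compounds alone, the methyl-to-methoxy exchange gives a 1.2-fold higher number from compound 3 to compound 4 (0.09 log units; within the scatter) and is the first measured change to a group on this carbonyl carbon; within these two compounds, the added oxygen and hydrogen-bond acceptor count leave the number inside the scatter. Compound 4 also shows a 6.9-fold higher number from compound 2 to compound 4 (0.84 log units; beyond the scatter) and a 9.1-fold higher number from compound 1 to compound 4 (0.96 log units; beyond the scatter), so the higher numbers seen with acetyl relative to the butyl and isobutyl compounds also appear with methoxycarbonyl on the aromatic carbon, and none of the four compounds goes against this. The compounds shown carry no measurement that could explain either the flat step on the carbonyl carbon or the larger steps from the alkyl groups.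

As far as these compounds go, it remains open whether this flat response extends to other groups on the carbonyl carbon, such as an amine forming an amide, a hydroxyl forming a carboxylic acid, or a longer ester chain such as ethoxy. From the compounds shown here alone, it is also open whether the carbonyl itself goes with the higher numbers, a question that an ether such as methoxymethyl on the aromatic carbon would address.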